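Two Anilines on Two Cores Against Lung Cancer Cells

The source may hold more compounds than are shown below. What is called first, only, known or untested is meant among the compounds shown, and "the series" means these compounds.

Compound 1 `COc1cc2ncnc(Nc3cccc(Br)c3)c2cc1OCCCCC(=O)Nc1ccc(S(N)(=O)=O)cc1` gives 11400 nM in a functional assay on NCI-H1975 cells (Homo sapiens) for antiproliferative activity, read by MTT assay, with a stated time of 72 h; on this read-out lower numbers stand for stronger inhibition and higher numbers for weaker inhibition.
Compound 2 `COc1cc2ncnc(Nc3ccc(C(F)(F)F)cc3)c2cc1OCCCCC(=O)Nc1ccc(S(N)(=O)=O)cc1` gives 12000 nM in this assay.
Compound 3 `NS(=O)(=O)c1ccc(NC(=S)Nc2ccc3ncnc(Nc4cccc(Br)c4)c3c2)cc1` gives 11000 nM in this assay.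

Compound 1 and compound 3 share the same aniline but sit on different cores; the difference between the two cores is not broken down here. Compound 2 carries 4-(trifluoromethyl)phenyl in place of 3-bromophenyl on a nitrogen on an aromatic ring, and the step this change makes is a 1.1-fold higher number from compound 1 to compound 2 (0.02 log units; within the scatter). The three measured values lie close together, and none of them stands apart from the others beyond the scatter.

Compound 4 `NS(=O)(=O)c1ccc(NC(=S)Nc2ccc3ncnc(Nc4ccc(C(F)(F)F)cc4)c3c2)cc1` is not yet measured. It relates to compound 3 exactly as compound 2 relates to compound 1: it carries 4-(trifluoromethyl)phenyl in place of 3-bromophenyl on a nitrogen on an aromatic ring, at a place whose surroundings read the same way in both pairs, so this is the same change. The expected step is a 1.1-fold higher number from compound 3 to compound 4 (0.04 log units; within the scatter), which rests on a 1.1-fold higher number from compound 1 to compound 2 (0.02 log units; within the scatter) and on compound 3 giving 11000 nM. For compound 4 the estimate in this assay is therefore 12000 nM, with a range from 6000 nM to 24000 nM.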

Compound 4, half-maximal inhibitory concentration: 17100 nM
The estimate for compound 4 lay 1.4-fold (0.15 log units) below the measured number; the range from low to high includes it.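

In this assay, the change from 3-bromophenyl to 4-(trifluoromethyl)phenyl on the second core gives a 1.6-fold higher number from compound 3 to compound 4 (0.19 log units; within the scatter). Set beside the step on the first core, this step does not differ from it: the same change on two cores in this assay, a 1.1-fold higher number (0.02 log units; within the scatter) from compound 1 to compound 2 and a 1.6-fold higher number (0.19 log units; within the scatter) from compound 3 to compound 4, 1.5-fold (0.17 log units) apart, within the scatter of two such steps. Within the data shown here, the change therefore carries over between these two cores with no step that stands out from the scatter, but this is an agreement between two small steps in only two pairs, and it does not show that the change would behave the same way on a third core or that it would ever move the number beyond the scatter.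

The compounds shown leave open whether another group on the aniline ring, such as an amine or a carboxylic acid, would separate the values on either core. They also leave open what a shorter or longer chain would do on the core of compound 1, and whether a carboxylic acid in place of the sulfonamide would alter the picture.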